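The compounds below may be only part of what the source reports. "The series", "measured", "known", "first", "only" and "open" are said of these compounds alone.

Working notes on the series.

Compound 1 `Cc1ccccc1NC1=C/C(=N/NC(N)=S)C(=O)N=C1Nc1ccccc1C` and compound 2 `NC(=S)N/N=C1/C=C(Nc2ccc(F)cc2)C(Nc2ccc(F)cc2)=NC1=O` share a group of 4 heavy atoms on a double-bonded nitrogen and differ elsewhere in the molecule; the difference between the two cores is not broken down here. In a functional assay on Bel-7402 cells (Homo sapiens) for antiproliferative activity, read by MTT assay, with a stated time of 72 h (on this read-out higher numbers stand for weaker inhibition and lower numbers for stronger inhibition), compound 1 gives 1710 nM. In this assay compound 2 gives 3660 nM, the second highest of the three numbers, with compound 1 nearest and compound 3 furthest.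

Compound 3 `Cc1ccccc1NC1=C/C(=N/N=C(\N)SCc2ccccc2)C(=O)N=C1Nc1ccccc1C` is compound 1 with the group of 11 heavy atoms in place of the group of 4 heavy atoms, on a double-bonded nitrogen (a group of 11 heavy atoms (8 carbon, 2 nitrogen, 1 sulfur; one six-membered aromatic ring of carbon only) in place of a group of 4 heavy atoms (1 carbon, 2 nitrogen, 1 sulfur; no ring), on a double-bonded nitrogen). In this assay compound 3 gives 17100 nM. The step is a 10-fold higher number from compound 1 to compound 3 (1.00 log units; beyond the scatter), so within this pair the larger group goes with weaker inhibition.

Compound 4 `N/C(=N\N=C1\C=C(Nc2ccc(F)cc2)C(Nc2ccc(F)cc2)=NC1=O)SCc1ccccc1` is not yet measured. It is compound 2 carrying the same change (a group of 11 heavy atoms (8 carbon, 2 nitrogen, 1 sulfur; one six-membered aromatic ring of carbon only) in place of a group of 4 heavy atoms (1 carbon, 2 nitrogen, 1 sulfur; no ring), on a double-bonded nitrogen); the surroundings of the place are the same word for word, a double-bonded nitrogen whose other neighbour is a carbon with a double bond to nitrogen, so this is the same change on the core of compound 2. The change has been seen once only, on the core of compound 1, and whether it carries over to the core of compound 2 is not known.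

Compound 4 is therefore expected to give 36000 nM in this assay, with an expected range from 12000 nM to 110000 nM. Among the compounds with values here, the expected step of a 9.8-fold higher number from compound 2 to compound 4 (0.99 log units; beyond the scatter) is set beside the measured 10-fold higher number from compound 1 to compound 3 (1.00 log units; beyond the scatter), because the only precedent is a 10-fold higher number from compound 1 to compound 3 (1.00 log units; beyond the scatter) and nothing shows the core of compound 2 behaving differently.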

Compound 4, half-maximal inhibitory concentration: 7690 nM
Compound 4: middle estimate off by 4.7-fold (0.67 log units), on the high side; the measured number lies below the stated range.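

In this assay the group of 11 heavy atoms in place of the group of 4 heavy atoms, on a double-bonded nitrogen, gives a 2.1-fold higher number from compound 2 to compound 4 (0.32 log units; beyond the scatter) and so moves the number the same way on the core of compound 2 as on the core of compound 1, but the size of the step does not carry over: the same change on two cores in this assay, a 10-fold higher number (1.00 log units; beyond the scatter) from compound 1 to compound 3 and a 2.1-fold higher number (0.32 log units; beyond the scatter) from compound 2 to compound 4, 4.8-fold (0.68 log units) apart, beyond the scatter of two such steps

Across these two pairs, then, the direction of the change is shared, while its size depends on the core it is made on, and a step measured on one core is a poor guide to the size of the step on the other. What this does not show is which part of the cores sets the size, as the two cores differ in more than one place and the pairs do not separate those differences. Two pairs also give no rule for any further core, so even the shared direction stands for these compounds only.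

The compounds shown leave open how a methyl thioether or an ethyl thioether, in the same place on a double-bonded nitrogen, would compare with the group of 11 heavy atoms. They also leave open how the change would behave on a core carrying chlorine or methoxy groups, which would show whether the size of the step follows the substituents of the core.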